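Swapping a cyclohexenyl for a tolyl group on the triazole

A few compounds are considered here, and "the series" means these few. Any claim that something is new, unique, unknown or untested is made for them only; others in the source may bear on it.

Measured so far:
- compound 1 `O=C1NC(O)(CCn2cc(C3=CCCCC3)nn2)C(OCc2ccccc2)=C1OCc1ccccc1`: 13100 nM
- compound 2 `CC(C)(C)c1ccc(-c2cn(C/C=C3\OC(=O)C(OCc4ccccc4)=C3OCc3ccccc3)nn2)cc1`: 51200 nM
- compound 3 `COC1=C(OC)C(O)(CCn2cc(-c3ccc(C(C)(C)C)cc3)nn2)NC1=O`: 11300 nM

All three compounds were tested in a functional assay on MDA-MB-231 cells (Homo sapiens) for antiproliferative activity, read by MTT assay, with a stated time of 24 h; a lower number here means a stronger inhibitor, a higher number a weaker inhibitor. Among these numbers, compound 1 stands second highest; compound 3 lies closest to it, and the two values fall within the usual scatter of such measurements, so no order can be read between them. Compound 2 gives a markedly higher number, a gap that lies beyond the scatter.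

Compound 4 `Cc1ccc(-c2cn(CCC3(O)NC(=O)C(OCc4ccccc4)=C3OCc3ccccc3)nn2)cc1` keeps the core of compound 1 and changes only the group on the triazole: 4-methylphenyl in place of cyclohex-1-en-1-yl on an aromatic carbon. For the measured compounds named here, no measured pair in this set shows this exact change, so its effect is unknown. Both groups are six-membered carbon rings of similar size, and the rest of the molecule is untouched, so the expectation for compound 4 is a step of a 1.1-fold lower number from compound 1 to compound 4 (0.04 log units; within the scatter) that does not go beyond the scatter in either direction. Compound 4 is therefore estimated at 12000 nM, with a range from 5000 nM to 30000 nM.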

Compound 4, half-maximal inhibitory concentration: 82200 nM
Compound 4: the middle estimate sits 6.9-fold (0.84 log units) below what was measured, outside the stated range (above it).
By their numbers in this assay, from the lowest: compounds 3 and 1 (each within the scatter of the next); then compounds 2 and 4 (each within the scatter of the next).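

In this assay replacing cyclohex-1-en-1-yl with 4-methylphenyl on the triazole gives a 6.3-fold higher number from compound 1 to compound 4 (0.80 log units; beyond the scatter) and so makes compound 4 the weaker inhibitor of this pair, which shows that this position does distinguish between two six-membered carbon rings. For the compounds shown here, none of the earlier compounds formed a pair that differed only here, so this is the first direct reading of the position. The step joins two differences, an aromatic ring in place of a non-aromatic one and an added methyl group, and no measurement shown here explains why the number rises.

Whether the ring or the methyl group accounts for the step remains open, and a plain phenyl group at this place could separate the two. As far as these compounds go, how a saturated cyclohexyl group or an amine-bearing ring would behave here also remains unknown.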